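The compounds below may be only part of what the source reports. "The series", "measured", "known", "first", "only" and "open" are said of these compounds alone.

Measured compounds and their values in a functional assay on HeLa cells (Homo sapiens) for cytotoxicity, read by MTT assay; a lower number here means a stronger inhibitor, a higher number a weaker inhibitor:
compound 1, `CCC(C)(O)CC(=O)O[C@H](CC=C(C)C)C1=CC(=O)c2c(O)ccc(O)c2C1=O`: 25200 nM
compound 2, `CC(C)=CC[C@@H](OC(=O)c1ccco1)C1=CC(=O)c2c(O)ccc(O)c2C1=O`: 80300 nM
compound 3, `CCCCC(C)(O)CC(=O)O[C@H](CC=C(C)C)C1=CC(=O)c2c(O)ccc(O)c2C1=O`: 60600 nM

Compound 3 holds the second highest of the three numbers. Its nearest neighbour is compound 2, where a 1.3-fold lower number from compound 2 to compound 3 (0.12 log units; within the scatter); its furthest is compound 1, where a 2.4-fold higher number from compound 1 to compound 3 (0.38 log units; beyond the scatter). The other measured step, a 3.2-fold higher number from compound 1 to compound 2 (0.50 log units; beyond the scatter), also stays within the ester series.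

Compound 4, `CCC(CO[C@H](CC=C(C)C)C1=CC(=O)c2c(O)ccc(O)c2C1=O)OC`, is not yet measured. It differs from compound 3 in one place: 2-methoxybutyl in place of (2-hydroxy-2-methylhexyl)carbonyl on an oxygen on a saturated carbon. Every measured step here swaps one acyl group for another on a carbonyl carbon or lengthens the chain of such a group; none removes the carbonyl itself and puts a 2-methoxybutyl on the oxygen. The three measured steps are all modest, and their sizes set the scale of what is known, but they do not point in a direction for this particular change. The expectation is therefore a step of modest size, direction uncertain, roughly a 1.1-fold lower number from compound 3 to compound 4 (0.04 log units; within the scatter), with the range kept wide.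

For compound 4 in this assay the estimate is 55000 nM, between 15000 nM and 200000 nM.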

Compound 4, half-maximal inhibitory concentration: 63500 nM
Beside the measured number, compound 4's estimate is 1.2-fold (0.06 log units) below it; the measured number falls inside the stated range.
By their numbers in this assay, from the lowest: compound 1; then compounds 3, 4 and 2 (each within the scatter of the next).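

In this assay, the carbonyl on this oxygen can go without the number separating from those of the two closest esters: a 1.0-fold higher number from compound 3 to compound 4 (0.02 log units; within the scatter), and a 1.3-fold lower number from compound 2 to compound 4 (0.10 log units; within the scatter), so 2-methoxybutyl on this oxygen sits level with both (2-hydroxy-2-methylhexyl)carbonyl and (furan-2-yl)carbonyl. The ester link is therefore not required to reach this level, although the comparison with compound 1 stands apart: a 2.5-fold higher number from compound 1 to compound 4 (0.40 log units; beyond the scatter), a step beyond the scatter, so compound 1 goes against any reading that the group on this oxygen makes no difference. Nothing measured here bears on the reason for this pattern.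

The compounds shown leave open whether the separation of compound 1 depends on its carbonyl or on its shorter chain, a question that the 2-hydroxy-2-methylbutyl ether on this oxygen would address directly. They also leave open whether the flat level among compounds 2, 3 and 4 would hold for an amine or a carboxylic acid at the end of the chain on this oxygen.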